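A Methoxyphenyl Variant in an Inactive Series

The compounds below may be only part of what the source reports. "The series", "measured", "known", "first", "only" and "open" are said of these compounds alone.

Compound 1 `COc1nc(C)c2c(C)ncnc2c1C#N` bears the shared core alone. In a functional assay on KB cells (Homo sapiens) for cytotoxicity, read by MTT assay, with a stated time of 3 days (a lower number here means a stronger inhibitor, a higher number a weaker inhibitor), compound 1 gives only a limit, > 50000 nM. Compound 2 `C=C1c2c(C)nc(OC)c(C#N)c2N=CN1CCC` carries a propyl chain. In this assay compound 2 likewise gives only a limit, > 50000 nM. Compound 3 `C=C1c2c(C)nc(OC)c(C#N)c2N=CN1Cc1ccco1` carries furan-2-yl on a saturated chain carbon bound to an amine nitrogen in a ring. In this assay compound 3 again gives only a limit, > 50000 nM. The step that the two limits leave unreadable from compound 2 to compound 3 cannot be sized because the limit of > 50000 nM in this assay, at which 3 of the 3 values shown sit, covers every value shown. Compound 3 thus stands among three values that are all limits, with no number to place it apart from the others.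

Compound 4 `C=C1c2c(C)nc(OC)c(C#N)c2N=CN1Cc1ccc(OC)cc1` differs from compound 3 in one place: 4-methoxyphenyl in place of furan-2-yl on a saturated chain carbon bound to an amine nitrogen in a ring. Among the measured compounds shown here, no measured step in this assay is readable, so none bears on this change with a size. Compound 4 is therefore expected to remain at the same limit, and the estimated step that the limit leaves unreadable from compound 3 to compound 4 is expected to be none beyond the scatter. Compound 4 is estimated at 60000 nM, within 20000 nM to 200000 nM.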

Compound 4, half-maximal inhibitory concentration: 670 nM
Beside the measured number, compound 4's estimate is 90-fold (1.95 log units) above it; measured number below the stated range.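

In this assay, the position on a saturated chain carbon bound to an amine nitrogen in a ring turns out to be one where a single change separates a measurable value from the limit: 4-methoxyphenyl in place of furan-2-yl gives an at least 74-fold lower number from compound 3 to compound 4 (1.87 log units; beyond the scatter), and 4-methoxyphenyl in place of ethyl gives an at least 74-fold lower number from compound 2 to compound 4 (1.87 log units; beyond the scatter). Both steps are measured against a limit, so each gives only the smallest size the step can have, while the step from compound 2 to compound 3 cannot be read. Compound 4 is the only compound here with a number rather than a limit: the limit of > 50000 nM in this assay, at which 3 of the 4 values shown sit.

The compounds shown leave open whether the six-membered aromatic ring or its methoxy group carries this step. A plain phenyl or a 4-hydroxyphenyl on the same carbon would separate the two.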